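This account rests on a few compounds, and the source may have more. Where it says the series, first, only, none or still open, it means among the compounds named here.

Within the data shown here, compound 2 `CN1CCC(OC(=O)c2ccccc2Br)CC1` gives 1.21 in a functional assay on the whole organism with Mus musculus as the target; on this read-out higher numbers stand for higher potency (the scale is a negative logarithm) and lower numbers for lower potency; the only other number in hand, from compound 1 `COc1ccccc1C(=O)OC1CCN(C)CC1`, is 1.43, and the step of a number 0.22 log units lower from compound 1 to compound 2 (within the scatter) lies within the scatter, so the two compounds stand level. Compound 3 `CN1CCC(OC(=O)c2ccccc2C(F)(F)F)CC1` differs from compound 2 by trifluoromethyl in place of bromo on an aromatic carbon. Among the measured compounds shown here, the one measured step bears on this only loosely, as an exchange of the same aromatic substituent, and it was small, a number 0.22 log units lower from compound 1 to compound 2 (within the scatter). The step of a number 0.01 log units lower from compound 2 to compound 3 (within the scatter) is therefore expected to stay within the scatter. Compound 3 is estimated at 1.2, with a range from 0.8 to 1.6.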

Compound 3, logarithm of the reciprocal of the active concentration, log(1/C): 1.49
Beside the measured number, compound 3's estimate is 0.29 log units below it; the measured number falls inside the stated range.
By their numbers in this assay, from the lowest: compounds 2, 1 and 3 (each within the scatter of the next).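

In this assay, trifluoromethyl in place of bromo gives a number 0.28 log units higher from compound 2 to compound 3 (within the scatter), and trifluoromethyl in place of methoxy gives a number 0.06 log units higher from compound 1 to compound 3 (within the scatter). This place on the aromatic ring, ortho to a large group, thus takes a group of four heavy atoms with all three compounds standing level, so none of these three exchanges separates the compounds. No measurement in hand offers a reason for this. Open, on these data alone, is whether an amine, a carboxylic acid or a longer chain at this place would stay level as well. Also open, as far as these compounds go, is how these groups behave elsewhere on the aromatic ring.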